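Chloro-to-hydrogen step on the fused core of compound 2

A few compounds are considered here, and "the series" means these few. Any claim that something is new, unique, unknown or untested is made for them only; others in the source may bear on it.

Of the compounds shown here, two carry numbers so far. In a functional assay on HCT-15 cells (Homo sapiens) for cytotoxicity, read by sulforhodamine B assay, with a stated time of 48 h (on this read-out lower numbers stand for stronger inhibition of growth and higher numbers for weaker inhibition of growth), compound 1 `ClCc1ccc(Cn2cnc3c(Cl)ncnc32)cc1` gives 1950 nM. In this assay compound 2 `ClCc1ccccc1Cn1cnc2c(Cl)nc(Cl)nc21` gives 330 nM, the lowest of the two numbers; the nearest other number, that of compound 1, sits beyond the scatter above it. Compound 1 and compound 2 differ in more than one place, so no single-change step can be read from them.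

Compound 3 `ClCc1ccccc1Cn1cnc2c(Cl)ncnc21` is not yet measured. It differs from compound 2 in one place: hydrogen in place of chloro on an aromatic carbon. Going by the values given here, no measured pair isolates this change, so the expected size of the step in this assay rests on judgement alone; a shift toward a higher number, probably beyond the scatter but not large, is expected, with a wide range.

The estimate for compound 3 in this assay is 900 nM, with a range from 300 nM to 2700 nM. The expected step is a 2.7-fold higher number from compound 2 to compound 3 (0.44 log units; beyond the scatter).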

Compound 3, concentration for 50% growth inhibition: 2090 nM
The estimate for compound 3 lay 2.3-fold (0.37 log units) below the measured number; the measured number falls inside the stated range.
By their numbers in this assay, from the lowest: compound 2; then compounds 1 and 3 (each within the scatter of the next).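

Chloro on the aromatic carbon between two ring nitrogen atoms matters in this assay: hydrogen in its place gives a 6.3-fold higher number from compound 2 to compound 3 (0.80 log units; beyond the scatter) and is the only single-change step read so far. The earlier compounds shown here could not separate this position from the other differences between them, whereas this pair does so, with the remaining structure unchanged. Nothing on hand accounts for the size of this step.

From the compounds shown here alone, this single pair shows only that chloro and hydrogen differ at this position, so it remains open how an amine, a methoxy group or a bromo group on the same carbon would read. Going by these compounds, it also remains open whether the step keeps its size when the chloro on the other aromatic carbon of the shared core is replaced by an amine.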